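Solubility notes: piperidinylmethyl to difluoromethoxybenzyl on the imide nitrogen

The source may report more compounds than this note shows. Statements on the series, on what has been measured and on what is new or still open speak of the compounds shown alone.

The series shares a fused imide core with a methyl-bearing pyridine ring. Compound 1 `Cc1nc(C(=O)O)c(N)c2c1C(=O)N(Cc1ccccc1)C2=O` carries a carboxylic acid and a benzyl group, and in a physicochemical assay for solubility, using the shake flask method, in simulated intestinal fluid, measured as kinetic solubility, with a stated time of 2 h, at 25 degrees C, at pH 6.5 (on this read-out higher numbers stand for higher solubility and lower numbers for lower solubility), compound 1 gives 177000 nM. Compound 2 `Cc1nc(C(=O)NC#N)c(N)c2c1C(=O)N(Cc1ccccc1)C2=O` gives 185000 nM; the step of a 1.0-fold higher number from compound 1 to compound 2 (0.02 log units; within the scatter) is within the scatter. Compound 3 `Cc1noc(-c2nc(C)c3c(c2N)C(=O)N(CC2CCNCC2)C3=O)n1` replaces the acid with a methyl-oxadiazole and the benzyl with a piperidin-4-ylmethyl group; in this assay compound 3 gives 160000 nM, a number within the scatter of both compound 1 and compound 2, so none of the three can be ranked against the others.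

Compound 4 `Cc1noc(-c2nc(C)c3c(c2N)C(=O)N(Cc2ccc(OC(F)F)cc2)C3=O)n1` differs from compound 3 by 4-(difluoromethoxy)phenyl in place of piperidin-4-yl on a saturated chain carbon bound to an amide-type nitrogen in a ring. Among the measured compounds shown here, no measured step touches this position; the only measured step concerns the carbonyl substituent and offers no guidance. Compound 1 and compound 3, which differ at this position and elsewhere, show values within the scatter of each other. The change removes the sole hydrogen-bond donor of the leaving group, and for compound 4 a step of a 6.4-fold lower number from compound 3 to compound 4 (0.81 log units; beyond the scatter) is expected, giving an estimated 25000 nM with a range from 4000 nM to 120000 nM.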

Compound 4, solubility: < 5000 nM
Compound 4 was reported as a limit (the forecaster's own chance of this, stated with the estimate: 5%); middle value at least 5.0-fold (0.69 log units) away from the limit.
By their numbers in this assay, from the lowest: compounds 3, 1 and 2 (each within the scatter of the next). At a limit, below all of these: compound 4.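

In this assay, among the compounds shown here, the change at the saturated chain carbon bound to an amide-type nitrogen in a ring gives the first measured step at this position: an at least 32-fold lower number from compound 3 to compound 4 (1.50 log units; beyond the scatter). Compound 4 stands only as a limit, so the step gives a bound on the size of the change and not its exact size: the limit of < 5000 nM in this assay, at which 1 of the 4 values shown sits. The only earlier step, at the carbonyl substituent, lay within the scatter, so this is the first single change shown that lies beyond it.

This exchange replaces a saturated ring with an aromatic one and adds the difluoromethoxy group at once, and the compounds shown do not separate these two parts. From the compounds shown here alone, it also remains open where a 4-methoxyphenyl or 4-aminophenyl group at this place would fall with the methyl-oxadiazole kept.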